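A Third Fluorine on the Phenethyl Ether Side Chain

A few compounds are considered here, and "the series" means these few. Any claim that something is new, unique, unknown or untested is made for them only; others in the source may bear on it.

Compound 2 `Cc1nc(C)c([C@H](OC(C)(C)C)C(=O)O)c(N2CCC(C)(C)CC2)c1-c1ccc(OCCc2ccc(F)c(F)c2)cc1` sits at the ceiling of an ADME assay on microsomes from liver (Homo sapiens) for metabolic stability, read by LC-MS, tested at 0.5 uM (on this read-out lower numbers stand for a shorter-lived compound and higher numbers for a longer-lived compound), where compound 2 gives > 2 h, a limit of the assay rather than a number. Compound 1 `COc1ccc(CCOc2ccc(-c3c(C)nc(C)c([C@H](OC(C)(C)C)C(=O)O)c3N3CCC(C)(C)CC3)cc2)cc1` likewise gives > 2 h in this assay, again only a limit. The step that the two limits leave unreadable from compound 1 to compound 2 is therefore unreadable, as the limit of > 2 h in this assay, at which 2 of the 2 values shown sit, shows. Compound 3 `Cc1nc(C)c([C@H](OC(C)(C)C)C(=O)O)c(N2CCC(C)(C)CC2)c1-c1ccc(OCCc2cc(F)c(F)cc2F)cc1` differs from compound 2 by fluoro in place of hydrogen on an aromatic carbon. With both measured values at the limit, no readable step bears on this change, so compound 3 is expected to stay at the limit, with a step that the limit leaves unreadable from compound 2 to compound 3 not beyond the scatter. Compound 3 is estimated at 3 h, between 1.5 h and 8 h.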

Compound 3, half-life: > 2 h
Compound 3: only a limit was reported (the forecaster's own chance of this, stated with the estimate: 85%); the middle value does not contradict the limit.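

No step can be read among compound 1, compound 2 and compound 3, since each gives only a limit: the limit of > 2 h in this assay, at which 3 of the 3 values shown sit.

From the compounds shown here alone, how far any of them lies past that limit, and whether the added fluoro changes the half-life at all, stays open.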